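Terminal group swap on the amide nitrogen

This account rests on a few compounds, and the source may have more. Where it says the series, first, only, none or still open, it means among the compounds named here.

Values measured in an assay on L1210 cells for inhibition of Thymidylate synthase (Mus musculus); on this read-out lower numbers stand for stronger inhibition and higher numbers for weaker inhibition:
compound 1 `C#CCN(Cc1ccc2nc(C)nc(O)c2c1)c1ccc(C(=O)N[C@@H](CCC(=O)O)C(=O)N2CCCC2C(=O)O)cc1` gives 35 nM
compound 2 `C#CCN(Cc1ccc2nc(C)nc(O)c2c1)c1ccc(C(=O)N[C@@H](CCC(=O)O)C(=O)NC(C)(C)C(=O)O)cc1` gives 42 nM
compound 3 `Cc1nc(O)c2cc(CN(C)c3ccc(C(=O)N[C@@H](CCC(=O)O)C(=O)N(C)[C@@H](CCC(=O)O)C(=O)O)c(F)c3)c(C)cc2n1` gives 3 nM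

Compound 2 carries the highest of the three numbers; compound 1 sits nearest, within the scatter, and compound 3 furthest, beyond it. For the measured compounds named here, compound 3 differs from compound 2 in more than one place, so its value alone shows no single step. Compound 4 `C#CCN(Cc1ccc2nc(C)nc(O)c2c1)c1ccc(C(=O)N[C@@H](CCC(=O)O)C(=O)N[C@@H](CCC(=O)O)C(=O)O)cc1` differs from compound 2 by 1,3-dicarboxypropyl in place of 1-carboxy-1-methylethyl on an amide-type nitrogen. Going by the values given here, the only measured change at this position, a 1.2-fold higher number from compound 1 to compound 2 (0.08 log units; within the scatter), was flat, so a terminal group swap has so far moved this assay little. A small gain is nonetheless expected for compound 4 in this assay, a 1.7-fold lower number from compound 2 to compound 4 (0.23 log units; within the scatter). Compound 4 is therefore estimated at 25 nM in this assay, with a range from 10 nM to 60 nM.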

Compound 4, inhibition constant: 2 nM
Compound 4: middle estimate off by 13-fold (1.10 log units), on the high side; the whole stated range lies above it.
By their numbers in this assay, from the lowest: compounds 4 and 3 (each within the scatter of the next); then compounds 1 and 2 (each within the scatter of the next).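

At the amide-type nitrogen, the terminal group is not as silent as the earlier flat step suggested: in this assay, 1,3-dicarboxypropyl in place of 1-carboxy-1-methylethyl gives a 21-fold lower number from compound 2 to compound 4 (1.32 log units; beyond the scatter). The change from 2-carboxypyrrolidin-1-yl to (1,3-dicarboxypropyl)amino on the carbonyl carbon is similarly large, at an 18-fold lower number from compound 1 to compound 4 (1.24 log units; beyond the scatter). No evidence is available on what underlies these steps.

Still open, as far as these compounds go, is whether the steps follow the extra carboxylic acid, the chain carrying it or the defined stereocentre. A chain ending in an amine on the same nitrogen would test the role of the terminal carboxylic acid.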